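Biaryl sulfonamide series: liver fraction stability notes

This account rests on a few compounds, and the source may have more. Where it says the series, first, only, none or still open, it means among the compounds named here.

Measured compounds:
Compound 1 `COc1ccccc1-c1cccc(S(=O)(=O)N2CCC(N3CCC(C)CC3)CC2)c1`: 0.25 h
Compound 2 `CC1CCN(C2CCN(S(=O)(=O)c3cccc(-c4ccc5ccccc5c4)c3)CC2)CC1`: 3.4 h
Compound 3 `CC1CCN(C2CCN(S(=O)(=O)c3cccc(-c4ccccc4C(F)(F)F)c3)CC2)CC1`: 0.617 h

In an ADME assay on S9 fraction from liver (Mus musculus, strain ICR/CD-1) for metabolic stability, read by LC-MS, using NADPH, with a stated time of 5 min, tested at 2 uM (on this read-out higher numbers stand for a longer-lived compound and lower numbers for a shorter-lived compound), compound 3 stands second highest of the three numbers, with compound 1 nearest and compound 2 furthest from it. Compound 4 `Cc1ccc(-c2cccc(S(=O)(=O)N3CCC(N4CCC(C)CC4)CC3)c2)cc1` carries 4-methylphenyl in place of 2-(trifluoromethyl)phenyl on an aromatic carbon. Among the compounds with values here, two measured steps touch the ring that is exchanged here: a 2.5-fold higher number from compound 1 to compound 3 (0.39 log units; beyond the scatter) and a 5.5-fold lower number from compound 2 to compound 3 (0.74 log units; beyond the scatter). Compound 1 and compound 3, which each carry a substituted phenyl where compound 2 carries naphthalen-2-yl, both give the shorter half-lives in this assay. Within the data shown here, no measured step removes the trifluoromethyl from that ring, so the size of this change is uncertain. Compound 4 is expected to stay near compound 3, with a 1.5-fold lower number from compound 3 to compound 4 (0.19 log units; within the scatter), within the scatter. The estimate for compound 4 is 0.4 h, range 0.15 h to 1.1 h.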

Compound 4, half-life: 1.92 h
Estimate against measurement, compound 4: 4.8-fold (0.68 log units) below, outside the stated range (above it).
By their numbers in this assay, from the lowest: compound 1; then compound 3; then compounds 4 and 2 (each within the scatter of the next).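

In this assay, 4-methylphenyl on this aromatic carbon separates compound 4 from the two compounds with a 2-substituted phenyl ring (a 3.1-fold higher number from compound 3 to compound 4 (0.49 log units; beyond the scatter); a 7.7-fold higher number from compound 1 to compound 4 (0.89 log units; beyond the scatter)), so a single substituted phenyl ring does not by itself give a short half-life here. Replacing naphthalen-2-yl with 4-methylphenyl stays within the scatter (a 1.8-fold lower number from compound 2 to compound 4 (0.25 log units; within the scatter)). Nothing at hand accounts for these differences.

The step from compound 3 to compound 4 changes both the substituent and its place on the phenyl ring, and the effects of the two cannot be separated. From the compounds shown here alone, how 2-methylphenyl, 4-(trifluoromethyl)phenyl or a phenyl ring carrying an amine or a carboxylic acid would behave remains open.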